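Swapping a Hydroxylated Pyridine for an Ethylamino Pyrazine

The source may report more compounds than this note shows. Statements on the series, on what has been measured and on what is new or still open speak of the compounds shown alone.

Compound 1 `COc1cccnc1-c1cc(Cl)ccc1NS(=O)(=O)c1ccc(C(C)(C)C)cc1` gives 958 nM in a functional assay on isolated protein for antagonist activity at C-C chemokine receptor type 9 (Homo sapiens), read by calcium flux, with a stated time of 10 min; on this read-out higher numbers stand for weaker inhibition and lower numbers for stronger inhibition.
Compound 2 `CC(C)(C)c1ccc(S(=O)(=O)Nc2ccc(Cl)cc2-c2nccc(CO)c2O)cc1` gives 8.7 nM in this assay.

For the measured compounds named here, compound 2 stands at the lower of the two numbers, and the only measured step, a 110-fold lower number from compound 1 to compound 2 (2.04 log units; beyond the scatter), shows how strongly the group attached to the shared core can move the read-out when it is exchanged on the same aromatic carbon.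

Compound 3 `CCNc1nccnc1-c1cc(Cl)ccc1NS(=O)(=O)c1ccc(C(C)(C)C)cc1` has not yet been measured. It differs from compound 2 by a group of 9 heavy atoms (6 carbon, 3 nitrogen; one six-membered aromatic ring with 2 hetero atoms) in place of a group of 9 heavy atoms (6 carbon, 1 nitrogen, 2 oxygen; one six-membered aromatic ring with 1 hetero atom), on an aromatic carbon. Going by the values given here, the group that leaves is the one whose arrival in compound 2 coincided with the large drop seen from compound 1; the group that enters is a different heterocycle, and nothing measured here contains it. Among the compounds with values here, the step from compound 1 to compound 2 is therefore the only guide, and it argues that removing the group of compound 2 is likely to cost potency, although how far the new ring compensates is unknown.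

Compound 3 is expected to land at 300 nM, within 50 nM to 2000 nM, which would mean an estimated step of a 34-fold higher number from compound 2 to compound 3 (1.54 log units; beyond the scatter).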

Compound 3, half-maximal inhibitory concentration: 421 nM
The estimate for compound 3 lay 1.4-fold (0.15 log units) below the measured number, and the stated range covers the measured number.
By their numbers in this assay, from the lowest: compound 2; then compound 3; then compound 1.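

In this assay, heavy-atom count alone does not set the result at this aromatic carbon: the leaving and entering groups each have 9 heavy atoms, yet the exchange gives a 48-fold higher number from compound 2 to compound 3 (1.68 log units; beyond the scatter). The ethylamino pyrazine still beats the group on compound 1, with a 2.3-fold lower number from compound 1 to compound 3 (0.36 log units; beyond the scatter), so a second kind of ring also gives a lower number than compound 1, but by a much smaller step than the hydroxylated pyridine of compound 2 gives. No measurement here explains why these groups differ, including whether the change from 2 hydrogen-bond donors to 1 plays any part.

The compounds shown leave open which part of the hydroxylated pyridine matters most, the hydroxyl, the hydroxymethyl or the ring itself, and a pyridine carrying only one of those two groups would help separate them. They also leave open how much the ethyl chain contributes on the pyrazine, which a plain amino group or a longer propylamino chain in its place would begin to show.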